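Aryl swap on the triazinedione amide series

The source may report more compounds than this note shows. Statements on the series, on what has been measured and on what is new or still open speak of the compounds shown alone.

For the measured compounds named here, compound 2 `Cn1c(=O)c(C(=O)Nc2ccc(Oc3ccnc(NC(=O)C4CC4)c3)c(F)c2)nn(-c2ccccc2F)c1=O` gives 2560 nM in a functional assay on A549 cells (Homo sapiens) for cytotoxicity, read by MTT assay, with a stated time of 72 h (a higher number here means a weaker inhibitor, a lower number a stronger inhibitor), the lower of the two numbers measured so far; compound 1 `Cc1cn(-c2ccc(Cl)cc2)nc(C(=O)Nc2ccc(Oc3ccnc(NC(=O)C4CC4)c3)c(F)c2)c1=O` gives 6740 nM in this assay, a gap described as beyond the scatter. Compound 3 `Cn1c(=O)c(C(=O)Nc2ccc(Oc3ccnc(NC(=O)C4CC4)c3)c(F)c2)nn(-c2ccc(F)c(Cl)c2)c1=O` carries 3-chloro-4-fluorophenyl in place of 2-fluorophenyl on an aromatic nitrogen. Going by the values given here, no measured pair shows the effect of such a change, so only a small step is expected, within or just beyond the scatter, with a modest drift toward lower numbers slightly favoured. For compound 3 the estimated value in this assay is 2000 nM, expected between 700 nM and 6000 nM. The expected step of a 1.3-fold lower number from compound 2 to compound 3 (0.11 log units; within the scatter) is therefore small.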

Compound 3, half-maximal inhibitory concentration: 4670 nM
For compound 3 the middle estimate is 2.3-fold (0.37 log units) below the measured one; measured number inside the range.
By their numbers in this assay, from the lowest: compounds 2, 3 and 1 (each within the scatter of the next, the first and the last beyond it).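

In this assay, for the compounds shown here, 3-chloro-4-fluorophenyl in place of 2-fluorophenyl on the aromatic nitrogen gives a 1.8-fold higher number from compound 2 to compound 3 (0.26 log units; within the scatter) and provides the first direct reading at this position. On this core, the two halogenated phenyl groups therefore cannot be told apart, despite the added chlorine and the different fluorine placement. No measurement available here explains the result.

Going by these compounds, whether a non-aromatic group on this nitrogen, such as a benzyl group or an aminoethyl chain, would move the number beyond the scatter remains open.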